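The source may hold more compounds than are shown below. What is called first, only, known or untested is meant among the compounds shown, and "the series" means these compounds.

Compounds measured in a functional assay on the whole organism for inhibition, with Rattus norvegicus as the target, read by paw edema, at a dose of 100 mg/kg by the oral route; a higher number here means more inhibition at the dose given (going by the name of the read-out), a lower number less inhibition:

Compound 1 `O=C(Nc1ccc(Cl)cc1)c1c(O)c2cccnc2n(-c2ccccc2)c1=O`: 11.6%
Compound 2 `O=C(Nc1ccc([N+](=O)[O-])cc1)c1c(O)c2cccnc2n(-c2ccccc2)c1=O`: -7.6%

Of the two numbers, compound 2 stands lowest; its nearest neighbour is compound 1, and the step of a number 19.2 percentage points lower from compound 1 to compound 2 (beyond the scatter) lies beyond the scatter. Compound 3 `Nc1ccc(NC(=O)c2c(O)c3cccnc3n(-c3ccccc3)c2=O)cc1` is not yet measured. The change from compound 2 to compound 3 is amino in place of nitro on an aromatic carbon.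

For the measured compounds named here, no measured step shares this change. Going by the values given here, the only step known, a number 19.2 percentage points lower from compound 1 to compound 2 (beyond the scatter), shows that replacing chloro by nitro on the aromatic carbon cost inhibition, so a group other than nitro in that place might recover some of it, but nothing in the data says how far. He therefore expects a modest rise, with wide uncertainty, in this assay for compound 3: a step of a number 15.6 percentage points higher from compound 2 to compound 3 (beyond the scatter). His estimate for compound 3 in this assay is 8%, within the range -15% to 30%.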

Compound 3, a percentage reported as inhibition, in the whole organism at one dose (the size of the read-out at that dose, not a potency): -5.5%
Estimate against measurement, compound 3: 13.5 percentage points above, within the range that was stated.
By their numbers in this assay, from the lowest: compounds 2 and 3 (each within the scatter of the next); then compound 1.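

In this assay, amino in place of nitro on the aromatic carbon gives a number 2.1 percentage points higher from compound 2 to compound 3 (within the scatter), so this swap does not recover the inhibition lost with nitro. Amino in place of chloro gives a number 17.1 percentage points lower from compound 1 to compound 3 (beyond the scatter), which runs the same way as a number 19.2 percentage points lower from compound 1 to compound 2 (beyond the scatter), so at this place, para to a large group, chloro stands apart from both nitrogen-bearing groups, while compound 2 and compound 3 cannot be told apart. No measurement is at hand that explains this result.

The compounds shown leave open whether another halogen, such as fluoro or bromo, or a methyl group would read like chloro, and whether a carboxylic acid would fall with nitro and amino. They also leave open whether plain hydrogen at this place would stand with compound 1 or with the other two.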